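Stretching the side chain of compound 3

The source may report more compounds than this note shows. Statements on the series, on what has been measured and on what is new or still open speak of the compounds shown alone.

In a functional assay on HL-60 cells (Homo sapiens) for antiproliferative activity, read by MTT assay, with a stated time of 48 h (a lower number here means a stronger inhibitor, a higher number a weaker inhibitor), compound 1 (`CCN(CC)CCn1c(N)c(-c2nc3ccccc3[nH]2)c2nc(C#N)c(C#N)nc21`) gives 1880 nM while compound 3 (`CCN(CC)CCn1c(N)c(-c2nc3ccccc3n2C)c2nc(C#N)c(C#N)nc21`) gives 8800 nM and so holds the higher of the two numbers. For compound 2 (`CN(C)CCn1c(N)c(-c2nc3ccccc3n2C)c2nc(C#N)c(C#N)nc21`) there is only a limit, > 50000 nM and no exact number. Compound 4 (`CCN(CC)CCCn1c(N)c(-c2nc3ccccc3n2C)c2nc(C#N)c(C#N)nc21`) turns the 2-(diethylamino)ethyl of compound 3 into 3-(diethylamino)propyl ((diethylamino)methyl in place of diethylamino on a saturated chain carbon, two bonds along the chain from an aromatic nitrogen). The closest guide is an at least 5.6-fold lower number from compound 2 to compound 3 (0.75 log units; beyond the scatter) for diethylamino in place of dimethylamino on the same chain. Methyl in place of hydrogen on an aromatic nitrogen gave a 4.7-fold higher number from compound 1 to compound 3 (0.67 log units; beyond the scatter) but touches a different part. Among the compounds with values here, no measured step lengthens the chain. The expected change in this assay is therefore small and within the scatter, namely a 1.4-fold lower number from compound 3 to compound 4 (0.13 log units; within the scatter) in the estimate. Compound 4 is expected at 6500 nM (estimated range 2000 nM to 25000 nM).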

Compound 4, half-maximal inhibitory concentration: 2810 nM
The estimate for compound 4 lay 2.3-fold (0.36 log units) above the measured number; measured number inside the range.
By their numbers in this assay, from the lowest: compounds 1 and 4 (each within the scatter of the next); then compound 3. At a limit, above all of these: compound 2.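

In this assay, going from 2-(diethylamino)ethyl to 3-(diethylamino)propyl gives a 3.1-fold lower number from compound 3 to compound 4 (0.50 log units; beyond the scatter), which shows that the length of the chain at this position matters, and not only the groups on its amine. Compound 2 carries a limit, not an exact number, and the larger step, an at least 17-fold lower number from compound 2 to compound 4 (1.25 log units; beyond the scatter), starts from that limit: the limit of > 50000 nM in this assay, at which 1 of the 4 values shown sits.

Going by these compounds, whether a still longer chain would lower the number further remains open. So does whether a piperidine ring could replace diethylamino on the 3-carbon propyl chain.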